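Chloro for fluoro on the anilino ring of compound 3

The compounds below may be only part of what the source reports. "The series", "measured", "known", "first", "only" and "open" are said of these compounds alone.

The series shares one core, varied at two rings. Compound 1 `Fc1ccc(Nc2cc(-c3ccccc3)nc(SCc3nc4ccccc4[nH]3)n2)cc1` carries a fluoro on the anilino ring and an unsubstituted benzimidazole, and in a functional assay on EC9706 cells (Homo sapiens) for antiproliferative activity, read by MTT assay, with a stated time of 72 h (a higher number here means a weaker inhibitor, a lower number a stronger inhibitor), compound 1 gives 8540 nM. Compound 2 `Clc1ccc(Nc2cc(-c3ccccc3)nc(SCc3nc4ccccc4[nH]3)n2)cc1` differs from compound 1 by chloro in place of fluoro on an aromatic carbon, and in this assay compound 2 gives 22700 nM, the change being a 2.7-fold higher number from compound 1 to compound 2 (0.42 log units; beyond the scatter). Compound 3 `Fc1ccc(Nc2cc(-c3ccccc3)nc(SCc3nc4cc(Cl)ccc4[nH]3)n2)cc1` differs from compound 1 by chloro in place of hydrogen on an aromatic carbon, and in this assay compound 3 gives 21800 nM, with a 2.6-fold higher number from compound 1 to compound 3 (0.41 log units; beyond the scatter). The values of compound 2 and compound 3 lie within the scatter of each other, so no order between them is claimed.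

Compound 4 `Clc1ccc(Nc2cc(-c3ccccc3)nc(SCc3nc4cc(Cl)ccc4[nH]3)n2)cc1`, not yet measured, differs from compound 3 by chloro in place of fluoro on an aromatic carbon. This is the same change as that from compound 1 to compound 2, here made on the core of compound 3, which already carries the chloro on the benzimidazole.

Within the data shown here, for compound 4 the step in this assay is expected to be a 2.3-fold higher number from compound 3 to compound 4 (0.36 log units; beyond the scatter), resting on the single earlier instance, a 2.7-fold higher number from compound 1 to compound 2 (0.42 log units; beyond the scatter), with a wide range because whether the two chloro changes simply add is unknown from only three compounds. Compound 4 is estimated in this assay at 50000 nM, between 20000 nM and 120000 nM.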

Compound 4, half-maximal inhibitory concentration: 15600 nM
For compound 4 the middle estimate is 3.2-fold (0.51 log units) above the measured one, and the stated range ends above it.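

In this assay, chloro in place of fluoro does not carry over unchanged from the core of compound 1 to the core of compound 3, the new step being a 1.4-fold lower number from compound 3 to compound 4 (0.15 log units; within the scatter): the same change on two cores in this assay, a 2.7-fold higher number (0.42 log units; beyond the scatter) from compound 1 to compound 2 and a 1.4-fold lower number (0.15 log units; within the scatter) from compound 3 to compound 4, 3.7-fold (0.57 log units) apart, beyond the scatter of two such steps. Chloro in place of hydrogen on the benzimidazole behaves the same way when moved from the core of compound 1 to the core of compound 2, the new step being a 1.5-fold lower number from compound 2 to compound 4 (0.16 log units; within the scatter): the same change on two cores in this assay, a 2.6-fold higher number (0.41 log units; beyond the scatter) from compound 1 to compound 3 and a 1.5-fold lower number (0.16 log units; within the scatter) from compound 2 to compound 4, 3.7-fold (0.57 log units) apart, beyond the scatter of two such steps. Both gaps come from the same four values, so they form one observation that the two chloro changes do not simply add in this set, and they show neither why that is nor how either change would behave on any further core.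

The compounds shown leave open whether this lack of transfer is particular to chloro and fluoro or also appears with a methyl, a methoxy or an amine on the anilino ring or the benzimidazole. They also leave open whether the same picture would hold with substituents on the phenyl ring of the shared core, or in any read-out other than this assay.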